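This account rests on a few compounds, and the source may have more. Where it says the series, first, only, none or still open, it means among the compounds named here.

In a functional assay on HEK293 cells (Homo sapiens), read by cAMP accumulation (on this read-out lower numbers stand for stronger inhibition and higher numbers for weaker inhibition), compound 1 `CCn1ccnc1-c1cccc(Cl)c1CCc1cc(Br)ccc1OC` gives 1800 nM, and compound 2 `CCCn1ccnc1-c1cccc(Cl)c1CCc1cc(Br)ccc1OC` gives 1900 nM. The step between them, (methyl in place of hydrogen on a saturated chain carbon, two bonds along the chain from an aromatic nitrogen), comes out as a 1.1-fold higher number from compound 1 to compound 2 (0.02 log units; within the scatter). Compound 3 `CCc1cn(C)c(-c2ccccc2CCc2cc(Br)ccc2OC)n1` is built on a different core; the difference between the two cores is not broken down here. In this assay compound 3 gives 820 nM, a number that stands beyond the scatter from both compound 1 and compound 2.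

Compound 4 `COc1ccc(Br)cc1CCc1ccccc1-c1nc(C(C)C)cn1C` has not yet been measured. It differs from compound 3 by methyl in place of hydrogen on a saturated chain carbon bound to an aromatic carbon and a saturated chain carbon. Among the compounds with values here, this is the same kind of change as the one from compound 1 to compound 2, though not the same: there the added methyl sat two bonds along the chain from an aromatic nitrogen, here it sits on a saturated chain carbon bound to an aromatic carbon and a saturated chain carbon, and cut one bond further out the change reads ethyl to isopropyl. Because the earlier step of a 1.1-fold higher number from compound 1 to compound 2 (0.02 log units; within the scatter) stayed within the scatter, compound 4 is expected to move little, by about a 1.1-fold higher number from compound 3 to compound 4 (0.04 log units; within the scatter). The estimate for compound 4 in this assay is 900 nM, with a range from 400 nM to 2000 nM.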

Compound 4, half-maximal inhibitory concentration: 1200 nM
For compound 4 the middle estimate is 1.3-fold (0.12 log units) below the measured one; low and high end bracket the measured number.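

Turning ethyl into isopropyl on the core of the later pair gives a 1.5-fold higher number from compound 3 to compound 4 (0.17 log units; within the scatter) in this assay. Set beside the earlier step, the methyl carries over from one core to the other without a difference that can be told from the scatter: the same change on two cores in this assay, a 1.1-fold higher number (0.02 log units; within the scatter) from compound 1 to compound 2 and a 1.5-fold higher number (0.17 log units; within the scatter) from compound 3 to compound 4, 1.4-fold (0.14 log units) apart, within the scatter of two such steps. Within the data shown here, this rests on only two pairs, with the methyl at different places: two bonds along the chain from an aromatic nitrogen in one, and on a saturated chain carbon bound to an aromatic carbon and a saturated chain carbon in the other, so it shows agreement for these pairs and no general rule for other cores or places.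

Still open, on these data alone, is whether a longer chain such as butyl, or a group carrying an amine or a carboxylic acid, would stay as close at these places. The compounds shown also leave open whether the same small steps would appear on any other read-out.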